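Arylpiperazine oxazoles: 3,4-dimethylphenyl replacing 2-chlorophenyl

The source may hold more compounds than are shown below. What is called first, only, known or untested is meant among the compounds shown, and "the series" means these compounds.

Measured so far:
compound 1 `CCCc1nc(-c2ccccc2)c(CNCCN2CCN(c3cccc(C(F)(F)F)c3)CC2)o1` – 1940 nM
compound 2 `CCCc1nc(-c2ccccc2)c(CNCCCN2CCN(c3ccccc3Cl)CC2)o1` – 2800 nM
compound 3 `CCCc1nc(-c2ccccc2)c(CNCCN2CCN(c3ccccc3C(F)(F)F)CC2)o1` – 2100 nM

All three values come from an assay on HEK293 cells for inhibition of Voltage-dependent T-type calcium channel subunit alpha-1G (Homo sapiens), read by patch clamp; on this read-out lower numbers stand for stronger inhibition and higher numbers for weaker inhibition. The numbers sit in a narrow band: compound 2 stands at the upper edge of it, but compound 3 and compound 1 both lie within the scatter of compound 2, so no order among the three can be claimed.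

Compound 4 `CCCc1nc(-c2ccccc2)c(CNCCCN2CCN(c3ccc(C)c(C)c3)CC2)o1` is not yet measured. It differs from compound 2 in one place: 3,4-dimethylphenyl in place of 2-chlorophenyl on an amine nitrogen in a ring. Among the compounds with values here, no measured pair shares a single-point change with compound 2 itself. Within the data shown here, the only measured step that bears on the question is the change of aryl group on the same ring nitrogen, a 1.1-fold higher number from compound 1 to compound 3 (0.03 log units; within the scatter); that step was within the scatter, which is the one hint available that swapping the aryl group on this amine nitrogen in a ring does little in this assay. It rests on a single pair, and a dimethyl pattern has not been tested, so the range is kept wide.

Compound 4 is therefore expected to stay close to compound 2, with an estimated step of no change at the digits printed from compound 2 to compound 4 (within the scatter). The estimate for compound 4 in this assay is 2800 nM, within a range of 1000 nM to 8000 nM.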

Compound 4, half-maximal inhibitory concentration: 3020 nM
Estimate against measurement, compound 4: 1.1-fold (0.03 log units) below, and the stated range covers the measured number.
By their numbers in this assay, from the lowest: compounds 1, 3, 2 and 4 (each within the scatter of the next).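

In this assay, within the data shown here, the change from 2-chlorophenyl to 3,4-dimethylphenyl on the amine nitrogen in a ring gives a 1.1-fold higher number from compound 2 to compound 4 (0.03 log units; within the scatter) and is the first single-place reading on the core of compound 2, where a chlorine-bearing aryl group gives way to an all-carbon one. Alongside a 1.1-fold higher number from compound 1 to compound 3 (0.03 log units; within the scatter) there are now two aryl swaps at this nitrogen, on two different cores and with different substitution patterns, and neither step lies beyond the scatter, so within these two pairs the choice of aryl group leaves the number unmoved and no pair goes against this. The data at hand hold no measurement that would account for this flat response.

Every aryl group shown here is a substituted phenyl carrying chlorine, trifluoromethyl or methyl, so it remains open whether a pyridine ring in its place, or a carboxylic acid or an amine on the phenyl, would move the number beyond the scatter. Also open, going by these compounds, is whether the same flat response would hold on a core with a longer chain between the two nitrogen-bearing parts.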